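A Substituted Phenyl on the Shared Core

The source may hold more compounds than are shown below. What is called first, only, known or untested is meant among the compounds shown, and "the series" means these compounds.

Measured so far in a physicochemical assay for solubility; on this read-out lower numbers stand for lower solubility and higher numbers for higher solubility:
- compound 1 `COc1ccc(-n2cnc3cnc(Nc4cccc(NC(C)=O)c4)cc32)cc1OC`: > 200000 nM (a limit of the assay)
- compound 2 `COc1ccc(-n2cnc3cnc(-c4cccc(NC(C)=O)c4)cc32)cc1OC`: 146000 nM
- compound 3 `COc1ccc(-n2cnc3cnc(-c4ccccc4)cc32)cc1OC`: 28000 nM

Compound 1 stands at > 200000 nM, which is a limit and not a number. Of the two true numbers in this assay, the lower belongs to compound 3 at 28000 nM, and the only other one, compound 2 at 146000 nM, is higher.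

The next compound to be read is compound 4 `COc1ccc(-n2cnc3cnc(-c4ccc(F)cc4C)cc32)cc1OC`. It carries 4-fluoro-2-methylphenyl in place of the phenyl of compound 3, on an aromatic carbon next to the ring nitrogen of the shared core: 4-fluoro-2-methylphenyl in place of phenyl on an aromatic carbon.

Among the compounds with values here, only one measured step bears on this change, and it bears only loosely. With hydrogen in place of acetamido on an aromatic carbon, the number falls in a 5.2-fold lower number from compound 2 to compound 3 (0.72 log units; beyond the scatter), a modest step beyond the scatter. That step removes acetamido, whereas the new change removes nothing from the phenyl ring and adds fluoro and methyl, so it gives the size of a possible move rather than a firm direction. A slight fall within the scatter is therefore expected, as the estimate a 1.4-fold lower number from compound 3 to compound 4 (0.15 log units; within the scatter) expresses. For compound 4 the estimated value in this assay is 20000 nM, with an expected range from 6000 nM to 60000 nM.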

Compound 4, solubility: > 200000 nM
Compound 4 gave a limit, no number (the forecaster's own chance of this, stated with the estimate: 3%); middle value at least 10-fold (1.00 log units) away from the limit.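

Replacing phenyl with 4-fluoro-2-methylphenyl on this aromatic carbon of the shared core gives an at least 7.1-fold higher number from compound 3 to compound 4 (0.85 log units; beyond the scatter). A higher number at this position therefore does not depend on acetamido, the only substituent on this phenyl ring shown before, whose replacement by hydrogen gave a 5.2-fold lower number from compound 2 to compound 3 (0.72 log units; beyond the scatter). The value of compound 4 in this assay is a limit, and it is the same limit that compound 1 reaches, so the size of this step remains open-ended: the limit of > 200000 nM in this assay, at which 2 of the 4 values shown sit.

The compounds shown leave open whether the fluoro or the methyl group accounts for the step, as neither appears alone on the phenyl ring, and whether the result depends on their placement at the 4 and 2 positions of 4-fluoro-2-methylphenyl. They also leave open how a morpholine or a carboxylic acid on that ring would read in this assay, and whether any such compound could be placed relative to compound 4 while its value remains a limit.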